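The source may hold more compounds than are shown below. What is called first, only, known or untested is meant among the compounds shown, and "the series" means these compounds.

In an assay on a cell-free system (plasma) for inhibition of Dipeptidyl peptidase 4 (Rattus norvegicus), read by fluorescence (a higher number here means a weaker inhibitor, a lower number a stronger inhibitor), compound 2 `O=C([C@@H]1C[C@H](N2CCN(c3ccccn3)CC2)CN1)N1CCSC1` gives 3.5 nM, the lowest of the three numbers recorded. Compound 1 `CN1CCN([C@@H]2CN[C@H](C(=O)N3CCSC3)C2)CC1` gives 81.1 nM, and compound 3 `O=C([C@@H]1C[C@H](N2CCN(c3cccc(Cl)c3)CC2)CN1)N1CCSC1` gives 7.2 nM. The steps of a 23-fold lower number from compound 1 to compound 2 (1.36 log units; beyond the scatter) and an 11-fold lower number from compound 1 to compound 3 (1.05 log units; beyond the scatter) were large, whereas a 2.1-fold higher number from compound 2 to compound 3 (0.31 log units; beyond the scatter) was modest. Compound 4 `N#Cc1ccc(N2CCN([C@@H]3CN[C@H](C(=O)N4CCSC4)C3)CC2)cc1` carries the change (4-cyanophenyl in place of pyridin-2-yl on an amine nitrogen in a ring). Among the compounds with values here, the only measured step that bears on replacing one aryl group by another is the modest one from compound 2 to compound 3, so a step of similar size, or none beyond the scatter, is expected here. For compound 4 the expected step is a 1.6-fold higher number from compound 2 to compound 4 (0.20 log units; within the scatter). The estimate for compound 4 in this assay is therefore 5.5 nM, with a range from 2.2 nM to 14 nM.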

Compound 4, half-maximal inhibitory concentration: 4.7 nM
The estimate for compound 4 lay 1.2-fold (0.07 log units) above the measured number, within the range that was stated.
By their numbers in this assay, from the lowest: compounds 2, 4 and 3 (each within the scatter of the next, the first and the last beyond it); then compound 1.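

In this assay a third aryl group on the amine nitrogen, 4-cyanophenyl, cannot be told apart from pyridin-2-yl, as a 1.3-fold higher number from compound 2 to compound 4 (0.13 log units; within the scatter) shows, or from 3-chlorophenyl, as a 1.5-fold lower number from compound 3 to compound 4 (0.19 log units; within the scatter) shows, although those two groups lie just beyond the scatter of each other. With a 17-fold lower number from compound 1 to compound 4 (1.24 log units; beyond the scatter) as a third large step, the gain over methyl holds for all three aryl groups shown. Going by these compounds, whether a carboxylic acid on the aryl ring, or a benzyl group on this nitrogen, would keep that level stays open. No measurement offered here accounts for these numbers.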